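Changing the Acetyl Arm of a Cytotoxic Indole Ylidene

A few compounds are considered here, and "the series" means these few. Any claim that something is new, unique, unknown or untested is made for them only; others in the source may bear on it.

Measured so far:
Compound 1, `COc1ccc(-c2[nH]c3ccccc3c2/C=C(\C#N)S(=O)(=O)c2ccccc2)cc1`: 300 nM
Compound 2, `CC(=O)/C(=C/c1c(-c2ccccc2)[nH]c2ccccc12)C(=O)c1ccccc1`: 8100 nM

Both numbers come from a functional assay on CCRF-CEM cells (Homo sapiens) for cytotoxicity, read by MTT assay, with a stated time of 96 h; on this read-out higher numbers stand for an effect only at larger amounts of compound and lower numbers for an effect already at smaller amounts. Compound 1 carries a nitrile and a sulfonyl group on its exocyclic double bond, and in this assay compound 1 gives 300 nM. Compound 2 instead carries two carbonyl groups on that double bond, and in this assay compound 2 gives 8100 nM. Of the two numbers shown, compound 2 stands highest; its gap to compound 1 is beyond the usual scatter, so compound 2 is the weaker of the pair on this read-out.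

The next compound, compound 3, `CCOC(=O)/C(=C/c1c(-c2ccccc2)[nH]c2ccccc12)C(=O)c1ccccc1`, differs from compound 2 in one place: ethoxy in place of methyl on a carbonyl carbon. In other words, the acetyl arm becomes an ethoxycarbonyl arm, a small change at the edge of the molecule while the core and the benzoyl arm stay the same. Among the measured compounds shown here, no measured pair shows what such a change does here, so there is no basis for expecting a large shift in either direction. The step from compound 2 to compound 3 is expected to be a 1.0-fold lower number from compound 2 to compound 3 (0.01 log units; within the scatter), within the scatter. Compound 3 is therefore estimated at 8000 nM, with a range from 2500 nM to 25000 nM.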

Compound 3, half-maximal effective concentration: 8000 nM
For compound 3 middle estimate and measured number coincide at the digits printed; low and high end bracket the measured number.
By their numbers in this assay, from the lowest: compound 1; then compounds 3 and 2 (each within the scatter of the next).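

Going a 1.0-fold lower number from compound 2 to compound 3 (0.01 log units; within the scatter) in this assay gives the first comparison in this series that differs in only one place, and the two numbers cannot be told apart. On a carbonyl carbon whose other neighbour is the double-bonded chain carbon, ethoxy, with 3 heavy atoms and 1 hydrogen-bond acceptor, can therefore take the place of methyl, with 1 heavy atom and no acceptor, without a measurable difference on this read-out. No supporting measurement is available to explain this result and a single pair cannot show whether the same would hold with other groups at this carbonyl carbon or in other parts of the molecule.

The compounds shown leave open whether this carbonyl carbon would accept a very different group just as readily, such as an amine, which would give an amide arm, a hydroxyl, which would give a carboxylic acid, or a longer chain such as butoxy. They also leave open what replacing the benzoyl arm, which stays the same in compound 2 and compound 3, would do to the number.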